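A Cyclopropylmethyl Group on a Clean Amino Compound

The source may report more compounds than this note shows. Statements on the series, on what has been measured and on what is new or still open speak of the compounds shown alone.

In an in vitro ADME assay on microsomes from liver (Rattus norvegicus) for metabolic stability (a higher number here means faster removal of the compound, a lower number slower removal), compound 3 `Nc1ccc(Cn2c(=O)[nH]c3c(N)nc(C(F)(F)F)cc32)cn1` gives < 10 mL.min-1.g-1 as a limit of the assay and not as a number. Compound 1 `Cc1ccc(Cn2c(=O)[nH]c3c(N)nc(C(F)(F)F)cc32)cn1` gives < 8.5 mL.min-1.g-1 as a limit too. Compound 2 `COc1ccc(Cn2c(=O)[nH]c3c(N)nc(C(F)(F)F)cc32)cn1` gives < 9 mL.min-1.g-1 as a limit as well.

Compound 4 `Nc1nc(C(F)(F)F)cc2c1[nH]c(=O)n2Cc1ccc(NCC2CC2)nc1` differs from compound 3 by cyclopropylmethyl in place of hydrogen on a nitrogen on an aromatic ring so that amino becomes (cyclopropylmethyl)amino.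

Among the compounds with values here, three measured steps bear on this change: a step that the two limits leave unreadable from compound 1 to compound 2 and a step that the two limits leave unreadable from compound 1 to compound 3 and a step that the two limits leave unreadable from compound 2 to compound 3 are all that these swaps on an aromatic carbon show. None of them gives a size to carry over, so the expectation rests on the structural change alone, with its added carbon atoms on that nitrogen. A modest upward move is expected, estimated as an at least 1.4-fold higher number from compound 3 to compound 4 (0.14 log units; that floor lies within the scatter) in this assay and resting on little support. For compound 4 the estimate is 14 mL.min-1.g-1 with an expected range from 6 mL.min-1.g-1 to 35 mL.min-1.g-1 in this assay and another reading at a limit would fit that expectation.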

Compound 4, intrinsic clearance in microsomes: 85 mL.min-1.g-1
Estimate against measurement, compound 4: 6.1-fold (0.78 log units) below; measured number outside the range, above it.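

Among compounds 1, 2 and 3, every value in this assay is a limit, so none of the steps between them can be read. Within the data shown here, compound 4 gives the first steps of readable size for a change at this place, all beyond the scatter: an at least 8.5-fold higher number from compound 3 to compound 4 (0.92 log units; beyond the scatter), an at least 9.4-fold higher number from compound 2 to compound 4 (0.97 log units; beyond the scatter) and an at least 10-fold higher number from compound 1 to compound 4 (1.00 log units; beyond the scatter). These sizes are floors and not exact steps, and compound 3, the closest comparison, is reported only as a limit: the limit of < 10 mL.min-1.g-1 in this assay, at which 1 of the 4 values shown sits.

From the compounds shown here alone, what stays open is whether the rise needs the three-membered ring of cyclopropylmethyl or follows from any added carbon chain on that nitrogen. Methylamino or butylamino in place of (cyclopropylmethyl)amino would separate these two readings, while the exact size of the step and its cause remain unsettled.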